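Cyano to hydroxy exchange on the terminal amide nitrogen

The source may hold more compounds than are shown below. What is called first, only, known or untested is meant among the compounds shown, and "the series" means these compounds.

Working notes on the series. Compound 1 `CCCCNC(=O)[C@@H](NC(=O)c1cccc(Cn2ccnc2)c1)[C@@H](C)CC` is recorded in an assay on HEK293 cells for displacement of a labelled ligand from Type-2 angiotensin II receptor (Homo sapiens), tested at 1 uM (a lower number here means a weaker effect, a higher number a stronger effect of the compound at the concentration tested), as "not active" (no number reported). Compound 2 `CCCCS(=O)(=O)NNC(=O)[C@@H](NC(=O)c1cccc(Cn2ccnc2)c1)[C@@H](C)CC` has in this assay only "not determined" (no result reported). Compound 3 `CC[C@H](C)[C@H](NC(=O)c1cccc(Cn2ccnc2)c1)C(=O)NC#N` is the sole entry with a figure: in this assay compound 3 gives 6%, a read-out that lies within the usual scatter of zero. Compound 4 `CC[C@H](C)[C@H](NC(=O)c1cccc(Cn2ccnc2)c1)C(=O)NO` differs from compound 3 in one place: hydroxy in place of cyano on an amide-type nitrogen. Going by the values given here, no step between two measured compounds is available, so nothing indicates what this exchange does to the read-out. Without a comparison pair, the step expected here is a number 1 percentage points lower from compound 3 to compound 4 (within the scatter), none beyond the scatter. For compound 4 the estimate in this assay is 5%, with a range from -10% to 20%.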

Compound 4, a percentage reported as inhibition, at one concentration (the size of the read-out at that concentration, not a potency): "not active" (no number reported)
Compound 4: no number reported, and the estimate cannot be compared.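

Going by these compounds alone, compound 4 carries no number, so no step from compound 3 to compound 4 can be read. The compounds shown leave open what hydroxy in place of cyano does to the read-out. No evidence bears on this result.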